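The compounds below may be only part of what the source reports. "The series", "measured", "known", "first", "only" and "open" are said of these compounds alone.

Compound 1 `CN(C)CCNc1nc(-c2ccc(NC(=O)Nc3ccc(Cl)cc3)cc2)nc2c(Cl)c(Cl)sc12`: 870 nM
Compound 2 `CN(C)CCNc1nc(-c2ccc(NC(=O)Nc3ccccc3Cl)cc2)nc2c(Cl)c(Cl)sc12`: 1350 nM
Compound 3 `CCN(CC)CCCNc1nc(-c2ccc(NC(=O)Nc3ccc(Cl)cc3)cc2)nc2ccsc12`: 230 nM

These three compounds were tested in a functional assay on MDA-MB-231 cells (Homo sapiens) for cytotoxicity, read by MTT assay, with a stated time of 72 h; a lower number here means a stronger inhibitor, a higher number a weaker inhibitor. Compound 1 and compound 2 share one core, and compound 3 has another; the difference between the two cores is not broken down here. Compound 3 gives the lowest number of the three, and its steps to compound 1 and to compound 2 both lie beyond the usual scatter of this kind of measurement. Within the first core, one change has been made: 2-chlorophenyl in place of 4-chlorophenyl on an amide-type nitrogen. This gave a 1.6-fold higher number from compound 1 to compound 2 (0.19 log units; within the scatter), a shift that stays within the scatter. Compound 4 `CCN(CC)CCCNc1nc(-c2ccc(NC(=O)Nc3ccccc3Cl)cc2)nc2ccsc12` is not yet measured; it carries the same change, on the core of compound 3: 2-chlorophenyl in place of 4-chlorophenyl on an amide-type nitrogen. Within the data shown here, the only example of this change so far, from compound 1 to compound 2, moved the number little, so a similarly small shift is expected here, though a single example is a thin basis. The step is expected to be a 1.5-fold higher number from compound 3 to compound 4 (0.18 log units; within the scatter). Compound 4 is therefore estimated at 350 nM in this assay, with a likely range from 150 nM to 900 nM.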

Compound 4, half-maximal inhibitory concentration: 500 nM
Compound 4: middle estimate off by 1.4-fold (0.15 log units), on the low side, and the stated range covers the measured number.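

In this assay, 2-chlorophenyl in place of 4-chlorophenyl on the amide-type nitrogen gives a 2.2-fold higher number from compound 3 to compound 4 (0.34 log units; beyond the scatter). Among these compounds, the number rises on both cores, and the two steps do not differ by more than the scatter, so the change carried over from one core to the other about as the first example suggested: the same change on two cores in this assay, a 1.6-fold higher number (0.19 log units; within the scatter) from compound 1 to compound 2 and a 2.2-fold higher number (0.34 log units; beyond the scatter) from compound 3 to compound 4, 1.4-fold (0.15 log units) apart, within the scatter of two such steps This is only two pairs, however, and only the step on the core of compound 3 lies beyond the scatter, so it shows neither why the number moves nor that a third core would behave the same way.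

The cores of compound 1 and compound 3 also differ in more than one place, so the compounds shown do not separate the effect of the amine side chain from that of the rest of the core. From the compounds shown here alone, it also remains open how a phenyl ring carrying a fluorine or a methoxy group instead of chlorine would fare, or how a morpholine would compare with the open-chain amines at the end of the side chain.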